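Extending an Alkoxy Chain on Two Related Cores

The source may report more compounds than this note shows. Statements on the series, on what has been measured and on what is new or still open speak of the compounds shown alone.

Measured so far:
compound 1, `CCCCOc1ccc2c(Cl)ccnc2c1`, giving 3610 nM in a functional assay on BGC-823 cells (Homo sapiens) for cytotoxicity, read by MTT assay, with a stated time of 48 h; a higher number here means a weaker inhibitor, a lower number a stronger inhibitor
compound 2, `CCCCCCCCOc1ccc2c(Cl)ccnc2c1`, giving 4300 nM
compound 3, `CCOc1ccc2c(NCCN(C)C)ccnc2c1`, giving 2520 nM

Compound 1 and compound 2 share one core and differ by butyl in place of hydrogen on a saturated chain carbon, four bonds along the chain from an oxygen on an aromatic ring. The step was a 1.2-fold higher number from compound 1 to compound 2 (0.08 log units; within the scatter). Compound 3 carries a different core; the difference between the two cores is not broken down here, and the values of compound 1 and compound 3 lie within the scatter of each other, as do those of compound 2 and compound 3.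

Compound 4, `CCCCCCOc1ccc2c(NCCN(C)C)ccnc2c1`, differs from compound 3 by butyl in place of hydrogen on a saturated chain carbon, two bonds along the chain from an oxygen on an aromatic ring. The place is not the same as before: in compound 1 the new butyl sits four bonds along the chain from the oxygen on the aromatic ring, in compound 3 two bonds along, so this is the same kind of change, not the same change. The step is expected to be a 1.2-fold higher number from compound 3 to compound 4 (0.08 log units; within the scatter), resting on the earlier change, which gave a 1.2-fold higher number from compound 1 to compound 2 (0.08 log units; within the scatter) on the other core. Compound 4 is therefore estimated at 3000 nM, between 1200 nM and 8000 nM.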

Compound 4, half-maximal inhibitory concentration: 1090 nM
Estimate against measurement, compound 4: 2.8-fold (0.44 log units) above; measured number outside the range, below it.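

On the second core, the added butyl gave a 2.3-fold lower number from compound 3 to compound 4 (0.36 log units; beyond the scatter) in this assay. Set beside the step on the first core, the same kind of change did not carry over, either in size or in direction: the same change on two cores in this assay, a 1.2-fold higher number (0.08 log units; within the scatter) from compound 1 to compound 2 and a 2.3-fold lower number (0.36 log units; beyond the scatter) from compound 3 to compound 4, 2.8-fold (0.44 log units) apart, beyond the scatter of two such steps. This shows that in this series the step seen on one core could not be taken as a guide to the step on the other, but it does not show what lies behind the gap: the two cores differ, the butyl stands four bonds along the chain from the oxygen in one pair and two bonds along in the other, and each step rests on a single pair of compounds.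

The compounds shown leave open whether a longer chain on the core of compound 4 would lower the number further or reverse the step. They also leave open how a matching chain on both cores would compare, and whether another amine in place of the dimethylamino group would keep the step seen here.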